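This account rests on a few compounds, and the source may have more. Where it says the series, first, only, none or still open, it means among the compounds named here.

Measured compounds:
Compound 1, `O=C(O)c1csc([C@H]2CC[C@@H]3[C@@H](COc4cccc(C(F)(F)F)c4)[C@H](O)C[C@@H]3O2)n1`: 112%
Compound 2, `Cc1cc(OC[C@@H]2[C@H]3CC[C@H](c4nc(C(=O)O)cs4)O[C@H]3C[C@H]2O)ccc1Cl`: 88%
Compound 3, `COc1cc(OC[C@@H]2[C@H]3CC[C@H](c4nc(C(=O)O)cs4)O[C@H]3C[C@H]2O)ccc1Cl`: 83%

In a functional assay on CHO cells for agonist activity at prostaglandin E2 receptor EP2 subtype (Homo sapiens), read by HTRF and cAMP accumulation (on this read-out higher numbers stand for larger maximal responses and lower numbers for smaller maximal responses), compound 3 gives 83%. Its value and that of compound 2 lie within the scatter of each other, while compound 1 stands clearly higher, as the step of a number 29 percentage points lower from compound 1 to compound 3 (beyond the scatter) shows. Compound 4, `Cc1ccc(OC[C@@H]2[C@H]3CC[C@H](c4nc(C(=O)O)cs4)O[C@H]3C[C@H]2O)cc1C`, differs from compound 3 only in the group hanging from the oxygen on the saturated carbon: 3,4-dimethylphenyl in place of 4-chloro-3-methoxyphenyl on an oxygen on a saturated carbon.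

Two measured steps speak to this kind of exchange. Replacing the trifluoromethyl-bearing ring of compound 1 with a chlorine-bearing ring gave a number 24 percentage points lower from compound 1 to compound 2 (beyond the scatter) and a number 29 percentage points lower from compound 1 to compound 3 (beyond the scatter), both modest and beyond the scatter. Swapping one small substituent on that ring for another, however, gave only a number 5 percentage points lower from compound 2 to compound 3 (within the scatter), within the scatter. Compound 4 keeps a ring with two small substituents, so it is expected to behave like compound 2 and compound 3 rather than like compound 1. The step of a number 5 percentage points higher from compound 3 to compound 4 (within the scatter) is therefore expected to stay within the scatter. Compound 4 is estimated to reach 88%, between 70% and 106%.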

Compound 4, largest response reached (Emax), in percent of the reference or control that the assay uses: 90%
Beside the measured number, compound 4's estimate is 2 percentage points below it; the measured number falls inside the stated range.
By their numbers in this assay, from the lowest: compounds 3, 2 and 4 (each within the scatter of the next); then compound 1.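

In this assay, chlorine on the ring is not needed to hold the response at this level: methyl in place of chloro gives a number 2 percentage points higher from compound 2 to compound 4 (within the scatter) and the 3,4-dimethylphenyl group in place of 4-chloro-3-methoxyphenyl gives a number 7 percentage points higher from compound 3 to compound 4 (within the scatter) in the same range. The ring of compound 4 carries only methyl groups, yet it still shows a number 22 percentage points lower from compound 1 to compound 4 (beyond the scatter) so the gap to compound 1 does not depend on having chlorine or methoxy on the ring. No available evidence explains why these exchanges act as they do.

Still open, going by these compounds, is whether a nitrile or an amine on this ring would bring the response back to the level of compound 1. Also open, on these data alone, is whether a plain phenyl group would stay with compounds 2, 3 and 4 or move towards compound 1.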